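A Second Fluorine on the Urea Phenyl Ring

The compounds below may be only part of what the source reports. "The series", "measured", "known", "first", "only" and "open" are said of these compounds alone.

Among the compounds with values here, in an assay on isolated protein for inhibition of serine/threonine-protein kinase 10 (Homo sapiens), read by thermal shift assay, tested at 10 uM (a higher number here means that the compound stabilises the target more against heat, a lower number that the compound stabilises the target less), compound 1 `CC(C)(C)c1cc(NC(=O)Nc2ccc(F)cc2)n(-c2ccccc2)n1` gives 6.5 degrees C, the higher of the two numbers measured so far. Within the data shown here, the only other measured compound, compound 2 `CC(C)(C)c1cc(NC(=O)Nc2cc(C(F)(F)F)cc(C(F)(F)F)c2)n(-c2ccccc2)n1`, carries two trifluoromethyl groups on the phenyl ring attached to the urea and gives -0.5 degrees C; the gap between these two values lies beyond the usual scatter of this assay. Among the measured compounds shown here, no pair of measured compounds differs in just one place, so there is no direct precedent for a single small change on this ring.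

Compound 3 `CC(C)(C)c1cc(NC(=O)Nc2ccc(F)c(F)c2)n(-c2ccccc2)n1` arises from compound 1 by the change (fluoro in place of hydrogen on an aromatic carbon). On the numbers available, the drop from compound 1 to compound 2 shows only that heavier substitution on this ring can remove the stabilisation seen with compound 1. For a single added fluorine the expected step is small, most likely a slight decrease or none beyond the scatter. Compound 3 is therefore expected to give 5.5 degrees C, within a range from 3 degrees C to 7.5 degrees C. This estimate implies a step of a number 1.0 degrees C lower from compound 1 to compound 3 (within the scatter) in this assay.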

Compound 3, shift of the target's melting temperature: 3.4 degrees C
The estimate for compound 3 lay 2.1 degrees C above the measured number; the measured number falls inside the stated range.
By their numbers in this assay, from the lowest: compound 2; then compound 3; then compound 1.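

In this assay, adding one fluoro to the 4-fluorophenyl ring of compound 1 gives a number 3.1 degrees C lower from compound 1 to compound 3 (beyond the scatter), so a change of a single heavy atom, on the aromatic carbon ortho to the fluoro group and meta to a large group, is enough to move the number beyond the scatter. The earlier compounds could not show this, as they differ in more than one place, and the stabilisation is reduced rather than gone, with compound 3 still giving 3.4 degrees C. Nothing measured here says why the number falls.

As far as these compounds go, it remains open whether this drop belongs to fluoro in particular or to any group on this carbon, which a chloro, methyl, methoxy or amino group in the same place would help to separate. From the compounds shown here alone, it is also open whether the step depends on the fluoro group already on the ring, a question that a 3-fluorophenyl compound, carrying the new fluoro alone, could address when set against a plain phenyl compound.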